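From bromo to hydrogen on the shared core

A few compounds are considered here, and "the series" means these few. Any claim that something is new, unique, unknown or untested is made for them only; others in the source may bear on it.

compound 1 `NC(=O)/C=C1\CCc2c(F)cc(F)cc21` gives 69 mg/kg
compound 2 `NC(=O)/C=C1\CCc2cc(F)cc(F)c21` gives 44 mg/kg
compound 3 `NC(=O)/C=C1\CCc2ccc(Br)cc21` gives 96 mg/kg

In a functional assay on the whole organism with Mus musculus as the target (a lower number here means that less compound is needed, a higher number that more compound is needed for the effect), compound 3 gives 96 mg/kg and lies within the scatter of compound 1, while its number is higher than that of compound 2 by a gap beyond the scatter. Compound 4 `NC(=O)/C=C1\CCc2ccccc21` is still unmeasured and carries hydrogen in place of bromo on an aromatic carbon in this comparison. Going by the values given here, no measured pair isolates a single change, so only the spread of values guides the expectation, with compound 1 at 69 mg/kg and compound 2 at 44 mg/kg as its reference points. The estimated 1.4-fold lower number from compound 3 to compound 4 (0.14 log units; within the scatter) is expected to be a small fall in the number, within the scatter. Compound 4 is expected at an estimated 70 mg/kg with a range from 35 mg/kg to 140 mg/kg in this assay overall.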

Compound 4, dose for half-maximal effect: 108 mg/kg
Estimate against measurement, compound 4: 1.5-fold (0.19 log units) below; low and high end bracket the measured number.
By their numbers in this assay, from the lowest: compounds 2, 1, 3 and 4 (each within the scatter of the next, the first and the last beyond it).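

In this assay, going by these compounds alone, the first comparison on the shared core that isolates a single change gives a 1.1-fold higher number from compound 3 to compound 4 (0.05 log units; within the scatter) when hydrogen takes the place of bromo on an aromatic carbon. At this position, meta to a fused ring and para to a fused ring, bromo and hydrogen cannot be told apart in this read-out. Nothing available explains this result.

As far as these compounds go, whether another group at this position, such as an amine, a carboxylic acid or a methoxy group, would shift the number remains open. So does the effect of a single fluoro there.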